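Swapping Chloro for Fluoro on the Chlorophenyl Group

The source may report more compounds than this note shows. Statements on the series, on what has been measured and on what is new or still open speak of the compounds shown alone.

Compound 3 `CC1CCN(c2c(S(=O)(=O)c3ccc(Cl)cc3)cnc3cc(F)ccc23)CC1` in an assay on isolated protein for displacement of a labelled ligand from metabotropic glutamate receptor 5 (Homo sapiens), with a stated time of 60 min, tested at 1 uM (a lower number here means less inhibition, a higher number more inhibition at the concentration tested (going by the name of the read-out)), gives 90%. Among the three measured compounds it stands second highest: compound 1 `CC1CCN(c2c(S(=O)(=O)c3ccc(Cl)cc3)cnc3cc(Cl)ccc23)CC1` is nearest, giving 91% in this assay, and compound 2 `Cc1ccc(S(=O)(=O)c2cnc3ccc(F)cc3c2N2CCC(C)CC2)cc1F` is furthest, giving 86% in this assay, yet all three values lie within the scatter of one another, so no order among them can be claimed. Compound 4 `CC1CCN(c2c(S(=O)(=O)c3ccc(F)cc3)cnc3cc(F)ccc23)CC1` has not yet been measured. It differs from compound 3 in one place: fluoro in place of chloro on an aromatic carbon.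

For the measured compounds named here, one measured step bears on this change. The same kind of exchange, fluoro in place of chloro on an aromatic carbon, gave a number 1 percentage points lower from compound 1 to compound 3 (within the scatter), a step that stayed within the scatter. Compound 3 already sits near the top of what this assay reports, so little room remains upward. The step from compound 3 to compound 4 is therefore expected to be a number 4 percentage points lower from compound 3 to compound 4 (within the scatter), a change no larger than the scatter, with at most a slight easing. Compound 4 is thus estimated at 86% in this assay, within a range from 72% to 95%.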

Compound 4, a percentage reported as inhibition, at one concentration (the size of the read-out at that concentration, not a potency): 74.5%
Compound 4: the middle estimate sits 11.5 percentage points above what was measured; low and high end bracket the measured number.
By their numbers in this assay, from the lowest: compound 4; then compounds 2, 3 and 1 (each within the scatter of the next).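

In this assay, exchanging 4-chlorophenyl for 4-fluorophenyl gave a number 15.5 percentage points lower from compound 3 to compound 4 (beyond the scatter) and so produced the first step among these compounds to pass beyond the scatter. The same kind of exchange at another place in the molecule had given a number 1 percentage points lower from compound 1 to compound 3 (within the scatter), so across these two steps, fluoro in place of chloro has no single outcome, and the place of the exchange matters in this pair of cases, with the chloro para to a large group being the one whose loss registers in the read-out. Nothing available here explains why the two steps differ or what the chloro on this ring contributes.

Going by these compounds, what a bromo, a methoxy, a nitrile or a plain hydrogen would give at this same place on the ring remains open, so it cannot yet be said whether the number with chloro is unusually high or the number with fluoro unusually low here. Also open, on these data alone, is whether the 4-chlorophenyl to 4-fluorophenyl exchange would give a step of similar size on the core of compound 1, and how far this single-concentration percentage reflects a real difference in potency.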